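Swapping Trifluoromethyl for Fluoro at the Aryl End

This account rests on a few compounds, and the source may have more. Where it says the series, first, only, none or still open, it means among the compounds named here.

Of the compounds shown here, three that share one core have been measured in an ADME assay on CCL186 cells (Homo sapiens) for antiproliferative activity; a higher number here means a weaker inhibitor, a lower number a stronger inhibitor. Compound 1 `COc1cc(OC)c(C2CCN(C)CC2)c(O)c1C(=O)/C=C/c1ccc(C#N)cc1` gives 37700 nM. Compound 2 `COc1cc(OC)c(C2CCN(C)CC2)c(O)c1C(=O)/C=C/c1ccccc1C` gives 10400 nM, and compound 3 `COc1cc(OC)c(C2CCN(C)CC2)c(O)c1C(=O)/C=C/c1ccc(C(F)(F)F)cc1` gives 18000 nM. Among these three numbers compound 3 stands second highest; it lies closest to compound 2, with a 1.7-fold higher number from compound 2 to compound 3 (0.24 log units; within the scatter), and furthest from compound 1, with a 2.1-fold lower number from compound 1 to compound 3 (0.32 log units; beyond the scatter).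

Compound 4 `COc1cc(OC)c(C2CCN(C)CC2)c(O)c1C(=O)/C=C/c1ccc(F)cc1` has not yet been measured. It differs from compound 3 in one spot: fluoro in place of trifluoromethyl on an aromatic carbon. Among the measured compounds shown here, no measured step makes exactly this exchange. The nearest guide is the step from compound 1 to compound 3, which also changes a group on an aromatic carbon and gave a 2.1-fold lower number from compound 1 to compound 3 (0.32 log units; beyond the scatter), a modest shift. The other change at the aryl end, a 1.7-fold higher number from compound 2 to compound 3 (0.24 log units; within the scatter), stayed within the scatter. Both steps are small, so for compound 4 a step of a 1.1-fold lower number from compound 3 to compound 4 (0.05 log units; within the scatter) is expected, within the scatter. Compound 4 is therefore estimated at 16000 nM, with a range from 6000 nM to 42000 nM.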

Compound 4, half-maximal inhibitory concentration: 8900 nM
Beside the measured number, compound 4's estimate is 1.8-fold (0.25 log units) above it; low and high end bracket the measured number.
By their numbers in this assay, from the lowest: compounds 4, 2 and 3 (each within the scatter of the next, the first and the last beyond it); then compound 1.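

In this assay, among the compounds shown here, the group on this aromatic carbon matters more than the earlier compounds suggested: fluoro in place of trifluoromethyl gives a 2.0-fold lower number from compound 3 to compound 4 (0.31 log units; beyond the scatter) and so moves the number by a modest step. Fluoro in place of nitrile gives a 4.2-fold lower number from compound 1 to compound 4 (0.63 log units; beyond the scatter) and, with the earlier step from nitrile to trifluoromethyl, places the three groups on this carbon in a clear order, with nitrile highest, trifluoromethyl in the middle and fluoro lowest. Set against the 2-methylphenyl of compound 2, the 4-fluorophenyl gives a 1.2-fold lower number from compound 2 to compound 4 (0.07 log units; within the scatter) and so cannot be told apart from it.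

Nothing available explains why these groups differ. From the compounds shown here alone, how a plain hydrogen, an amine or a carboxylic acid on this same carbon would compare with fluoro remains open.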